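This account rests on a few compounds, and the source may have more. Where it says the series, first, only, none or still open, it means among the compounds named here.

The measured compounds, in an assay on membranes from brain for displacement of a labelled ligand from Neuronal acetylcholine receptor; alpha4/beta2 (Rattus norvegicus); on this read-out higher numbers stand for weaker inhibition and lower numbers for stronger inhibition:

compound 1, `CN1CCC[C@H]1COc1cccnc1[N+](=O)[O-]`, 9000 nM
compound 2, `Cc1ccncc1OC[C@@H]1CCCN1C`, 4.12 nM
compound 3, `CN1CCC[C@H]1COc1cncc(Br)c1`, 0.27 nM

Of these three, compound 3 gives the lowest number in this assay, and both gaps lie beyond the scatter. The nearest of the others is compound 2 with 4.12 nM; the furthest is compound 1, which in this assay gives 9000 nM. All three share the same side chain, and they differ in the aromatic ring and what sits on it.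

Compound 4, `CCCc1cncc(OC[C@@H]2CCCN2C)c1`, is not yet measured. It differs from compound 3 in one place: propyl in place of bromo on an aromatic carbon. Among the measured compounds shown here, no measured pair in this set shows such a change, so its effect is not known from these data. Since the bromo compound stands at the low end of the set and the only other variations here move the number up, a step towards a higher number is expected, though short of the gap to compound 2.

The step from compound 3 to compound 4 in this assay is expected to be a 22-fold higher number from compound 3 to compound 4 (1.35 log units; beyond the scatter). For compound 4 the estimated value in this assay is 6 nM, with a range from 1.5 nM to 30 nM.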

Compound 4, inhibition constant: 0.12 nM
For compound 4 the middle estimate is 50-fold (1.70 log units) above the measured one; measured number below the stated range.
By their numbers in this assay, from the lowest: compound 4; then compound 3; then compound 2; then compound 1.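

In this assay, the aromatic carbon two atoms from the ring nitrogen takes propyl in place of bromo without any loss: the change gives a 2.3-fold lower number from compound 3 to compound 4 (0.35 log units; beyond the scatter), a modest step beyond the scatter. Among the compounds shown here, this carbon therefore carries a chain of 3 heavy atoms as well as it carries a single bromine, and the number falls further rather than rising, something the earlier compounds could not show, as none of them formed a pair differing at this place. No measurement at hand bears on the reason for this step.

On these data alone, whether a longer chain such as butyl, or a branched one such as isopropyl, would keep the number this low remains open. So does the effect of an amine or a carboxylic acid on the same carbon.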